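The compounds below may be only part of what the source reports. "The series", "measured", "known", "first", "only" and "open" are said of these compounds alone.

Measured compounds:
- compound 1 `N#CC1=C(N)OC(c2c[nH]c3ccccc23)=C(C#N)C1c1cccc2ccccc12`: 6.8%
- compound 2 `N#CC1=C(N)OC(c2c[nH]c3ccccc23)=C(C#N)C1c1ccccc1`: 19.3%
- compound 3 `N#CC1=C(N)OC(c2c[nH]c3ccccc23)=C(C#N)C1c1ccc2ccccc2c1`: "not active" (no number reported)

All three share one core and differ only in the aryl group on the saturated ring carbon. In a functional assay, tested at 100 ug/mL (a higher number here means a stronger effect of the compound at the concentration tested, a lower number a weaker effect), compound 2 gives 19.3%, the highest of the two numbers available; compound 1 gives 6.8%, and the step of a number 12.5 percentage points higher from compound 1 to compound 2 (beyond the scatter) lies beyond the scatter. Compound 3 is reported as "not active" (no number reported) without a number, so it cannot be placed against the other two on a scale.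

Compound 4 `N#CC1=C(N)OC(c2c[nH]c3ccccc23)=C(C#N)C1c1ccccc1F` has not been measured. Its difference from compound 2 is fluoro in place of hydrogen on an aromatic carbon. Within the data shown here, no measured step touches this kind of change: the single step on hand, from compound 1 to compound 2, swaps whole aryl groups, whereas here a single fluoro enters on the phenyl already present in compound 2. That step therefore gives no direction for the expected size, only the observation that the aryl group on this carbon does move this assay.

Among the measured compounds shown here, with no comparable step available, the expectation for compound 4 is a value close to that of compound 2, a number 1.3 percentage points lower from compound 2 to compound 4 (within the scatter) being expected to fall within the scatter. Compound 4 is estimated at 18%, with a range from 5% to 32%.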

Compound 4, a percentage reported as activity, at one concentration (the size of the read-out at that concentration, not a potency): "not active" (no number reported)
Compound 4: no number reported; no gap can be computed for the estimate.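

In this assay, among these compounds, compound 4 stands at "not active" (no number reported) and, like compound 3, carries no number, so no step from compound 2 to compound 4 can be read. Nothing available bears on this result. The compounds shown leave open how far phenyl and 2-fluorophenyl stand apart in this assay on a numerical scale.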